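Changing acetyl to methoxycarbonyl on an inactive compound

The compounds below may be only part of what the source reports. "The series", "measured", "known", "first", "only" and "open" are said of these compounds alone.

Measured so far in a functional assay on the whole organism for antagonist activity, with Mus musculus as the target; on this read-out higher numbers stand for an effect only at larger amounts of compound and lower numbers for an effect already at smaller amounts:
Compound 1 `CC(=O)N(C)CC#CCn1ccnc1`: > 100 mg/kg
Compound 2 `CC(=O)N(C)CC#CCn1cncc1C`: 6.6 mg/kg

In this assay compound 1 stands at > 100 mg/kg, which is a limit and not a number. Compound 3 `COC(=O)N(C)CC#CCn1ccnc1` keeps the core of compound 1 but has methoxy in place of methyl on a carbonyl carbon. This can also be read as acetyl to methoxycarbonyl.

For the measured compounds named here, the only measured step is large: an at least 15-fold lower number from compound 1 to compound 2 (1.18 log units; beyond the scatter). It comes from a different change, methyl in place of hydrogen on an aromatic carbon, so it bears only weakly on this one. Going by the values given here, no measured step involves the carbonyl carbon, so no clear gain is expected, and the result may again be only a limit. The expected change is a step that the limit leaves unreadable from compound 1 to compound 3. For compound 3 the estimated value is 120 mg/kg, with an expected range from 30 mg/kg to 400 mg/kg.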

Compound 3, dose for half-maximal effect: > 100 mg/kg
Compound 3: a limit, no number (the forecaster's own chance of this, stated with the estimate: 60%); the middle value lies beyond the limit too.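

Compound 1 and compound 3 both end at a limit and not a number, so no step between them can be read: the limit of > 100 mg/kg in this assay, at which 2 of the 3 values shown sit.

The compounds shown leave open whether methoxy in place of methyl on a carbonyl carbon changes the dose needed at all, and what it would do on compound 2.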